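A few compounds are considered here, and "the series" means these few. Any claim that something is new, unique, unknown or untested is made for them only; others in the source may bear on it.

Measured so far in a functional assay on OVCAR cells (Homo sapiens) for inhibition, read by MTT assay, with a stated time of 48 h; a higher number here means a weaker inhibitor of growth, a lower number a stronger inhibitor of growth:
compound 1 `O=[N+]([O-])c1ccc(-c2cc(-c3ccccc3)n[nH]2)cc1` gives 7200 nM
compound 2 `COc1ccc(-c2cc(-c3ccccc3-c3ccccc3)n[nH]2)cc1` gives 670 nM
compound 3 `COc1cccc(-c2cc(-c3ccccc3-c3ccccc3)n[nH]2)c1` gives 5800 nM

Compound 2 stands lowest of the three numbers in this assay. Going by the values given here, its nearest neighbour is compound 3, and the only single-point step in the set runs between these two: an 8.7-fold higher number from compound 2 to compound 3 (0.94 log units; beyond the scatter). Compound 1 sits furthest away, with a number roughly as far from compound 2 as compound 3 is.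

The next compound, compound 4 `O=[N+]([O-])c1ccc(-c2cc(-c3ccccc3-c3ccccc3)n[nH]2)cc1`, is reached from compound 2 by one change: nitro in place of methoxy on an aromatic carbon, in words a nitro in place of methoxy on an aromatic carbon.

Among the compounds with values here, no measured step speaks to this exchange directly. The step from compound 2 to compound 3 concerns the position of the methoxy, not its replacement. Within the data shown here, compound 1 carries the nitro but differs from compound 4 elsewhere, so its number and that of compound 2 only show that the nitro-bearing member of the set sits at the high end, and no step between them is given.

The expectation for compound 4 is therefore broad: a number somewhat higher than compound 2, estimated at 1500 nM, within 500 nM to 5000 nM. The estimated step is a 2.2-fold higher number from compound 2 to compound 4 (0.35 log units; beyond the scatter).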

Compound 4, concentration for 50% growth inhibition: 3400 nM
Compound 4: the middle estimate sits 2.3-fold (0.36 log units) below what was measured; the range from low to high includes it.
By their numbers in this assay, from the lowest: compound 2; then compounds 4, 3 and 1 (each within the scatter of the next, the first and the last beyond it).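

In this assay the aromatic carbon para to a large group now has a direct exchange, and nitro in place of methoxy gives a 5.1-fold higher number from compound 2 to compound 4 (0.71 log units; beyond the scatter) and thus a weaker inhibitor of growth, whereas the earlier step at the methoxy concerned only where it sits on the ring. Going by these compounds alone, compound 4 also gives the first reading of the added phenyl: phenyl in place of hydrogen on an aromatic carbon gives a 2.1-fold lower number from compound 1 to compound 4 (0.33 log units; beyond the scatter) in the nitro-bearing pair, a smaller step than the exchange of methoxy for nitro, though still beyond the scatter. Nothing available here accounts for either step.

Open, on these data alone, is whether an amine, a hydroxyl or an ethoxy at this place would give a number closer to that of compound 2 or to that of compound 4. Also open is whether the size of the phenyl step depends on the group at this place, as the only such step shown carries nitro.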